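Moving the Bromine on a Bromophenyl Amide

The source may report more compounds than this note shows. Statements on the series, on what has been measured and on what is new or still open speak of the compounds shown alone.

Of the compounds shown here, three sharing one core have been tested in a functional assay on SiHa cells (Homo sapiens) for inhibition, read by CCK-8 assay, with a stated time of 72 h, tested at 10 uM; a lower number here means less inhibition of growth, a higher number more inhibition of growth at the concentration tested. Compound 1 (`CN(C)C(=O)c1cc2cnc(Nc3ccc(NC(=O)C4(C(=O)Nc5cccc(O)c5)CC4)cc3)nc2n1C1CCCC1`) gives 75.7%, compound 2 (`CN(C)C(=O)c1cc2cnc(Nc3ccc(NC(=O)C4(C(=O)Nc5ccccc5F)CC4)cc3)nc2n1C1CCCC1`) gives 103%, and compound 3 (`CN(C)C(=O)c1cc2cnc(Nc3ccc(NC(=O)C4(C(=O)Nc5ccc(Br)cc5)CC4)cc3)nc2n1C1CCCC1`) gives 98.8%. Compound 3 therefore belongs to the upper pair of these numbers, and the data show a number 4.2 percentage points lower from compound 2 to compound 3 (within the scatter), as well as a number 23.1 percentage points higher from compound 1 to compound 3 (beyond the scatter).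

Compound 4 (`CN(C)C(=O)c1cc2cnc(Nc3ccc(NC(=O)C4(C(=O)Nc5cccc(Br)c5)CC4)cc3)nc2n1C1CCCC1`) has not yet been measured. It carries 3-bromophenyl in place of 4-bromophenyl on an amide-type nitrogen.

For the measured compounds named here, no measured step moves the bromine on its ring, so the evidence is indirect. Changes of the group at this nitrogen have mattered, with a number 27.3 percentage points higher from compound 1 to compound 2 (beyond the scatter) being modest and beyond the scatter. Yet the one step that joins the two upper compounds is a number 4.2 percentage points lower from compound 2 to compound 3 (within the scatter), which stays within the scatter. A small change is therefore expected, with the estimate being a number 4.8 percentage points lower from compound 3 to compound 4 (within the scatter). Compound 4 is expected to give 94%, with an estimated range of 77% to 106%.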

Compound 4, percent growth inhibition at one concentration: 92.5%
For compound 4 the middle estimate is 1.5 percentage points above the measured one, within the range that was stated.
By their numbers in this assay, from the lowest: compound 1; then compounds 4, 3 and 2 (each within the scatter of the next, the first and the last beyond it).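

Moving the bromine gives the first direct reading of this change on the amide-type nitrogen: in this assay the swap of 4-bromophenyl for 3-bromophenyl gives a number 6.3 percentage points lower from compound 3 to compound 4 (within the scatter) and so does not separate the two bromophenyl groups. The move does show a difference from the 2-fluorophenyl group, with a number 10.5 percentage points lower from compound 2 to compound 4 (beyond the scatter) where the 4-bromophenyl group gave only a number 4.2 percentage points lower from compound 2 to compound 3 (within the scatter) in the same comparison. With 3-bromophenyl and 3-hydroxyphenyl now both present, bromo in place of hydroxy on an aromatic carbon can be read as a single exchange, giving a number 16.8 percentage points higher from compound 1 to compound 4 (beyond the scatter) for that one group.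

As far as these compounds go, how an amine or a carboxylic acid on this phenyl ring would read in this assay remains open. The compounds shown also offer no measurement that explains any of these steps.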